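The source may hold more compounds than are shown below. What is called first, only, known or untested is meant among the compounds shown, and "the series" means these compounds.

Measured compounds:
Compound 1, `C[C@H](Oc1ccc2ncc(/C=C/C(N)=O)c(C3CC3)c2c1)c1c(Cl)ccc(F)c1Cl`. In a physicochemical assay for lipophilicity, using the shake flask method (a lower number here means a more polar compound, a higher number a more lipophilic compound), compound 1 gives > 5.5, which is a limit of the assay and not a number.
Compound 2, `C[C@H](Oc1ccc2ncc(/C=C/c3nn[nH]n3)c(C3CC3)c2c1)c1c(Cl)cccc1Cl`. In this assay compound 2 gives 4.3.

Among the compounds with values here, compound 2 holds the only numeric value shown; the other entry, for compound 1, is the limit of > 5.5 in this assay, at which 1 of the 2 values shown sits. Within the data shown here, no step between two measured compounds is available, so there is no measured change of the same kind to put beside the move to compound 3.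

Compound 3, `C[C@H](Oc1ccc2ncc(/C=C/c3nn[nH]n3)c(C(F)F)c2c1)c1c(Cl)cccc1Cl`, differs from compound 2 in one place: difluoromethyl in place of cyclopropyl on an aromatic carbon. Among the measured compounds shown here, no measured pair shows this exchange, so the size of the step in this assay has to be estimated rather than derived. A small step downward is expected, roughly at the edge of the usual scatter, a number 0.30 log units lower from compound 2 to compound 3 (within the scatter). Compound 3 is accordingly estimated at 4, with a range from 3.5 to 4.5.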

Compound 3, distribution coefficient: 3.3
Estimate against measurement, compound 3: 0.70 log units above, outside the stated range (below it).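

At this position, on an aromatic carbon opposite the ring nitrogen and ortho to a 2-(2H-tetrazol-5-yl)ethenyl group, the series now has its first measured step in this assay: difluoromethyl in place of cyclopropyl gives a number 1.00 log units lower from compound 2 to compound 3 (beyond the scatter). The position therefore responds to this exchange, even though the two groups have the same count of heavy atoms and neither has a hydrogen-bond donor or acceptor. Nothing shown accounts for the size of the step.

On these data alone, whether a trifluoromethyl group, a methyl group or an amine at this position would also lie lower than compound 2 remains open. Also open, as far as these compounds go, is whether the exchange gives a similar step with the amide side chain of compound 1, whose entry is a limit of the assay and not a number.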